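A few compounds are considered here, and "the series" means these few. Any claim that something is new, unique, unknown or untested is made for them only; others in the source may bear on it.

Measured so far in an assay on membranes from HEK293 cells for displacement of a labelled ligand from Translocator protein (Homo sapiens), read by scintillation counting, with a stated time of 90 min; a lower number here means a stronger inhibitor, a higher number a weaker inhibitor:
Compound 1 `CCN(CC)C(=O)c1nc2ccccc2n1Cc1ccc(Cl)cc1`: > 10000 nM, a limit of the assay rather than a number.
Compound 2 `CCN(CC)C(=O)c1cc2cc(C)ccc2n1Cc1cn[nH]n1`: > 10000 nM, again a limit.
Compound 3 `COc1ccc(CN(C(C)=O)c2cc(C)cc(C)c2)cc1`: 500 nM.

Compound 3 is the only one of the three with a numbered result; the other two sit at the limit of > 10000 nM in this assay, at which 2 of the 3 values shown sit. Compound 4 `CC(=O)N(Cc1ccc(OCCF)cc1)c1cc(C)cc(C)c1` is not yet measured. It differs from compound 3 in one place: fluoromethyl in place of hydrogen on a saturated chain carbon bound to an oxygen on an aromatic ring. Among the measured compounds shown here, no measured pair shows what this kind of change does, so there is nothing to lean on beyond the values of compound 3. The expected step from compound 3 to compound 4 in this assay is a 1.4-fold lower number from compound 3 to compound 4 (0.15 log units; within the scatter), small and within the usual scatter, with no clear direction. The estimate for compound 4 is therefore 350 nM, within 120 nM to 1000 nM.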

Compound 4, inhibition constant: 275 nM
Compound 4: middle estimate off by 1.3-fold (0.10 log units), on the high side; measured number inside the range.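

Replacing methoxy with 2-fluoroethoxy gives a 1.8-fold lower number from compound 3 to compound 4 (0.26 log units; within the scatter) in this assay, so this place tolerates the larger, fluorine-bearing chain with no change that can be told from the scatter. Among the compounds shown here, compound 3 and compound 4 form the only measured pair here that differs in one place, which makes this the only direct reading of such a change. Nothing measured here gives a reason for this step.

A plain ethoxy group would show whether the fluorine matters at all. From the compounds shown here alone, a longer chain, such as 3-fluoropropoxy, or an amine at this place remains open.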